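Linker change on compound 2: amine to sulfide

A few compounds are considered here, and "the series" means these few. Any claim that something is new, unique, unknown or untested is made for them only; others in the source may bear on it.

Compound 1 `COc1ccc(CNc2nc3cc(N)cc(N)c3nc2-c2ccccc2)cc1OC`, in a functional assay on LOX IMVI cells (Homo sapiens) for inhibition, read by sulforhodamine B assay, with a stated time of 48 h (a higher number here means a weaker inhibitor of growth, a lower number a stronger inhibitor of growth), compound 1 gives 14100 nM.
Compound 2 `Nc1cc(N)c2nc(-c3ccccc3)c(NCc3ccc(F)cc3)nc2c1`, in this assay compound 2 gives 3160 nM.
Compound 3 `COc1ccc(CNc2nc3cc(N)cc(N)c3nc2-c2ccccc2)cc1`, in this assay compound 3 gives 27500 nM.

Compound 2 gives the lowest number of the three in this assay; the nearest is compound 1, as a 4.5-fold lower number from compound 1 to compound 2 (0.65 log units; beyond the scatter), and the furthest is compound 3, as an 8.7-fold higher number from compound 2 to compound 3 (0.94 log units; beyond the scatter). Both steps that reach compound 2 change only the aromatic substituents on the benzyl group, and compound 1 to compound 3 is a 2.0-fold higher number from compound 1 to compound 3 (0.29 log units; within the scatter).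

Compound 4 `Nc1cc(N)c2nc(-c3ccccc3)c(Sc3ccc(F)cc3)nc2c1` differs from compound 2 by (4-fluorophenyl)sulfanyl in place of (4-fluorobenzyl)amino on an aromatic carbon. For the measured compounds named here, no measured step touches the linker between the shared core and the fluorinated ring, so none bears directly on this change; the fluorinated ring that compound 2 carries is kept. The step from compound 2 to compound 4 is therefore expected to be small, with its direction uncertain, and the estimate rests on compound 2 with 3160 nM. Compound 4 is expected to give 5000 nM in this assay, within 1500 nM to 20000 nM, which would mean a 1.6-fold higher number from compound 2 to compound 4 (0.20 log units; within the scatter).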

Compound 4, concentration for total growth inhibition: 40700 nM
Estimate against measurement, compound 4: 8.1-fold (0.91 log units) below, and the stated range ends below it.
By their numbers in this assay, from the lowest: compound 2; then compounds 1, 3 and 4 (each within the scatter of the next, the first and the last beyond it).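

In this assay, the linker itself proves to matter at this aromatic carbon: with the fluorinated ring kept, exchanging (4-fluorobenzyl)amino for (4-fluorophenyl)sulfanyl gives a 13-fold higher number from compound 2 to compound 4 (1.11 log units; beyond the scatter). The earlier steps shown here changed only the substituents on the benzyl ring and left the link to the shared core intact, so they could not show that this link alone can move the number this far. No available evidence gives a reason for the step.

This single change replaces the nitrogen with sulfur and also removes the chain carbon, so the compounds shown cannot say which of the two matters. On these data alone, a (4-fluorobenzyl)sulfanyl group or a (4-fluorophenyl)amino group at this carbon would separate these two changes, and whether either would keep the number of compound 2 remains open.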